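From 3-fluorobenzyl to 2,4-dichlorobenzyl in a level series

The source may report more compounds than this note shows. Statements on the series, on what has been measured and on what is new or still open speak of the compounds shown alone.

Measured in a functional assay on HeLa cells (Homo sapiens) for inhibition, with a stated time of 72 h (on this read-out lower numbers stand for an effect already at smaller amounts and higher numbers for an effect only at larger amounts of compound), so far:
Compound 1 `COc1cc(CNCc2ccncc2)ccc1OCc1ccccc1F` gives 5100 nM
Compound 2 `COc1cc(CNCc2ccncc2)ccc1OCc1ccc(C)cc1` gives 5000 nM
Compound 3 `COc1cc(CNCc2ccncc2)ccc1OCc1cccc(F)c1` gives 4800 nM

Compound 3 stands level with the other two compounds, as the data show a 1.0-fold lower number from compound 2 to compound 3 (0.02 log units; within the scatter) and a 1.1-fold lower number from compound 1 to compound 3 (0.03 log units; within the scatter) with neither step leaving the scatter. The change to compound 4 `COc1cc(CNCc2ccncc2)ccc1OCc1ccc(Cl)cc1Cl` is 2,4-dichlorophenyl in place of 3-fluorophenyl on a saturated chain carbon bound to an oxygen on an aromatic ring and, cut one bond further out, it reads 3-fluorobenzyl to 2,4-dichlorobenzyl. The measured steps that bear on it are the exchanges at that same place. Besides the two already given, there is a 1.0-fold lower number from compound 1 to compound 2 (0.01 log units; within the scatter) and so all three stay within the scatter, with no measured compound going against this. None of these compounds carries chlorine, however, so the new group has not been tried here, and the range is kept wide. Given a 1.1-fold lower number from compound 1 to compound 3 (0.03 log units; within the scatter) and a 1.0-fold lower number from compound 2 to compound 3 (0.02 log units; within the scatter) no step beyond the scatter is expected in this assay in either direction. The expected size is a 1.2-fold lower number from compound 3 to compound 4 (0.08 log units; within the scatter) by this estimate. For compound 4 the estimated value is 4000 nM with an expected range from 1800 nM to 8000 nM on this reckoning.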

Compound 4, half-maximal effective concentration: 3900 nM
For compound 4 the middle estimate is 1.0-fold (0.01 log units) above the measured one; low and high end bracket the measured number.
By their numbers in this assay, from the lowest: compounds 4, 3, 2 and 1 (each within the scatter of the next).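

The 2,4-dichlorophenyl group brings chlorine to this place, on a saturated chain carbon bound to an oxygen on an aromatic ring, and in this assay the series stays level: there is a 1.2-fold lower number from compound 3 to compound 4 (0.09 log units; within the scatter) and a 1.3-fold lower number from compound 2 to compound 4 (0.11 log units; within the scatter) and also a 1.3-fold lower number from compound 1 to compound 4 (0.12 log units; within the scatter) and each of these steps lies within the scatter. The exchanges at this place now span the 2-fluorophenyl, 3-fluorophenyl and 4-methylphenyl groups and a ring carrying two chlorine atoms, and no compound shown goes against this level picture, though it holds only for these four compounds and none of them can be set apart from the others. The data shown offer no evidence that would explain why these exchanges leave the number level.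

The compounds shown leave open whether this level picture would hold for a group of another kind at the same place, such as a carboxylic acid, an amine or a longer chain in place of the substituted phenyl ring. They also leave open whether a change elsewhere in the shared core would produce a step beyond the scatter in this assay at all.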